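From 2-methylphenyl to 5-methylfuran-2-yl on the shared core

The source may hold more compounds than are shown below. What is called first, only, known or untested is meant among the compounds shown, and "the series" means these compounds.

In a functional assay on HeLa cells (Homo sapiens) for cytotoxicity, in the presence of a further agent that is not named here (on this read-out lower numbers stand for stronger inhibition and higher numbers for weaker inhibition), compound 1 `Cc1cccc(-c2cc(-c3ccc(Cl)o3)cc(-c3ccsc3)n2)c1` gives 20300 nM and compound 2 `Cc1ccccc1-c1cc(-c2ccc(Cl)o2)cc(-c2ccsc2)n1` gives 9770 nM as the lower of the two numbers. Compound 3 `Cc1ccc(-c2cc(-c3ccc(Cl)o3)cc(-c3ccsc3)n2)o1` is not yet measured and differs from compound 2 by 5-methylfuran-2-yl in place of 2-methylphenyl on an aromatic carbon on an aromatic carbon next to the ring nitrogen. Within the data shown here, the only measured step of a 2.1-fold lower number from compound 1 to compound 2 (0.32 log units; beyond the scatter) exchanges 3-methylphenyl for 2-methylphenyl and offers no direct test of the 5-methylfuran-2-yl group. A similarly modest move toward a higher number is expected, estimated as a 1.3-fold higher number from compound 2 to compound 3 (0.12 log units; within the scatter) in this assay for now. For compound 3 the estimated value is 13000 nM with an expected range from 5000 nM to 32000 nM in this assay.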

Compound 3, half-maximal inhibitory concentration: > 50000 nM
Compound 3 ended at the assay's limit; the forecaster's own chance of this, stated with the estimate: 10%; at least 3.8-fold (0.58 log units) between middle value and limit.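

Compound 3 reads only as a limit in this assay: the limit of > 50000 nM in this assay, at which 1 of the 3 values shown sits.

At this aromatic carbon next to the ring nitrogen, 5-methylfuran-2-yl gives an at least 5.1-fold higher number from compound 2 to compound 3 (0.70 log units; beyond the scatter) and an at least 2.4-fold higher number from compound 1 to compound 3 (0.39 log units; beyond the scatter). Both steps run toward weaker inhibition, opposite in direction to the methyl shift among the methylphenyl groups, so the ring type here bears on the read-out, not only the methyl placement.

From the compounds shown here alone, the true size of both steps stays open, as does whether the ring oxygen or the ring size drives them. Going by these compounds, how an amine or a carboxylic acid at this carbon would read is also open.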